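Sulfonate series: methoxy in place of methyl, second site

The source may report more compounds than this note shows. Statements on the series, on what has been measured and on what is new or still open speak of the compounds shown alone.

Measured so far in a functional assay on MCF7 cells (Homo sapiens) for antiproliferative activity, read by sulforhodamine B assay, with a stated time of 48 h; on this read-out higher numbers stand for weaker inhibition and lower numbers for stronger inhibition:
compound 1 `Cc1ccccc1OS(=O)(=O)c1ccc(N2CCN(C)C2=O)cc1`, 5600 nM
compound 2 `COc1ccccc1OS(=O)(=O)c1ccc(N2CCN(C)C2=O)cc1`, 26000 nM
compound 3 `Cc1ccc(OS(=O)(=O)c2ccc(N3CCN(C)C3=O)cc2)cc1`, limit only, > 100000 nM

Compound 3 sits at the limit of this assay (the limit of > 100000 nM in this assay, at which 1 of the 3 values shown sits). The core difference from compound 1 to compound 3 is 4-methylphenyl in place of 2-methylphenyl on an oxygen, carrying an at least 17-fold higher number from compound 1 to compound 3 (1.25 log units; beyond the scatter); compound 2 against compound 3 shows an at least 3.8-fold higher number from compound 2 to compound 3 (0.58 log units; beyond the scatter).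

The change methoxy in place of methyl on an aromatic carbon gave a 4.6-fold higher number from compound 1 to compound 2 (0.67 log units; beyond the scatter). Compound 4 `COc1ccc(OS(=O)(=O)c2ccc(N3CCN(C)C3=O)cc2)cc1`, not yet measured, carries the same kind of change, (methoxy in place of methyl on an aromatic carbon), but here the place reads "para to a large group" where before it read "ortho to a large group".

Resting on compound 3 being only a limit and on the weakening seen in compound 1 to compound 2, the step from compound 3 to compound 4 is expected to be a step that the limit leaves unreadable from compound 3 to compound 4. Compound 4 is expected at 200000 nM, between 60000 nM and 800000 nM, most likely again as a limit.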

Compound 4, half-maximal inhibitory concentration: 95000 nM
Beside the measured number, compound 4's estimate is 2.1-fold (0.32 log units) above it; low and high end bracket the measured number.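

Methoxy in place of methyl does not carry over as a readable repeat from the core of compound 1 to the para position of compound 3: the same change on two cores in this assay, a 4.6-fold higher number (0.67 log units; beyond the scatter) from compound 1 to compound 2 and an at least 1.0-fold lower number (0.02 log units; that floor lies within the scatter) from compound 3 to compound 4, at least 4.8-fold (0.68 log units) apart, beyond the scatter of two such steps

Compound 3 is only a limit, > 100000 nM. Set against that limit, the change gives an at least 1.0-fold lower number from compound 3 to compound 4 (0.02 log units; that floor lies within the scatter), so its true size cannot be read, and the gap shows no true reversal. In this assay, the readable steps are a 3.7-fold higher number from compound 2 to compound 4 (0.56 log units; beyond the scatter) and a 17-fold higher number from compound 1 to compound 4 (1.23 log units; beyond the scatter).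

Open, going by these compounds, is whether an amine or a fluorine atom in place of the methoxy of compound 4 would give a number clear of the limit. Also open, on these data alone, is how a longer chain, such as ethoxy, would read at either place on the ring.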